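The compounds below may be only part of what the source reports. "The series", "measured", "known", "first", "only" and "open" are said of these compounds alone.

The measured compounds and their readings:

Compound 1, `COC(CCn1cnc2c(NCc3ccc(C(=O)Nc4ccccc4N)cc3)nc(Cl)nc21)OC`: in a functional assay on HCT-116 cells (Homo sapiens) for antiproliferative activity, read by CCK-8 assay, with a stated time of 72 h, tested at 8 uM (a higher number here means a stronger effect of the compound at the concentration tested, a lower number a weaker effect), compound 1 gives 11.9%.
Compound 2, `Nc1ccccc1NC(=O)/C=C/c1ccc(Cn2cnc3c(Nc4cccc(Cl)c4)nc(Cl)nc32)cc1`: compound 2 gives 15.8%.
Compound 3, `Nc1ccccc1NC(=O)/C=C/c1ccc(Cn2cnc3c(Nc4cccc(OC(F)(F)F)c4)nc(Cl)nc32)cc1`: compound 3 gives 5.23%.

All three compounds share the same core and differ only in the groups hung on it. Compound 1 lies within the usual scatter of both compound 2 and compound 3, so the three readings cannot be put in a reliable order; they all describe weak inhibition at the concentration used. Going by the values given here, the one step that is larger than the scatter, a number 10.6 percentage points lower from compound 2 to compound 3 (beyond the scatter), concerns a group that is not touched by the change considered here, so it offers no direct guide.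

Compound 4, `Nc1ccccc1NC(=O)c1ccc(CNc2nc(Cl)nc3c2ncn3C2CCCC2)cc1`, has not been measured. It differs from compound 1 as follows: cyclopentyl in place of 3,3-dimethoxypropyl on an aromatic nitrogen. Among the compounds with values here, no measured pair shows what swapping the group on that ring nitrogen does, so nothing supports expecting a shift beyond the scatter. The step expected is therefore small, a number 1.1 percentage points higher from compound 1 to compound 4 (within the scatter), and compound 4 is estimated to give 13% in this assay, within a range from 3% to 26%.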

Compound 4, a percentage reported as inhibition, at one concentration (the size of the read-out at that concentration, not a potency): 80.6%
Estimate against measurement, compound 4: 67.6 percentage points below; the measured number lies above the stated range.
By their numbers in this assay, from the lowest: compounds 3, 1 and 2 (each within the scatter of the next, the first and the last beyond it); then compound 4.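

In this assay, the group on this aromatic nitrogen proves to be a major control on the read-out: with the rest of the molecule unchanged, cyclopentyl in place of 3,3-dimethoxypropyl gives a number 68.7 percentage points higher from compound 1 to compound 4 (beyond the scatter). The earlier compounds shown here could not show this, as none of their measured steps involved a change at this nitrogen, so this pair gives the first direct view of the position. The swap alters several things at once, replacing an open chain of 7 heavy atoms with 2 oxygens by a five-membered carbon ring of 5 heavy atoms, and nothing available identifies which of these differences accounts for the jump.

The compounds shown do not separate the presence of a ring from the loss of the two oxygens, a distinction that a plain pentyl chain or a tetrahydropyranyl ring at the same nitrogen could help to draw. Also open, going by these compounds, is whether the same swap would raise the reading of compounds that differ elsewhere, such as compound 2, and how the result would translate into a potency, since this read-out comes from a single concentration.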